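From ester to ether on the shared core

The source may report more compounds than this note shows. Statements on the series, on what has been measured and on what is new or still open speak of the compounds shown alone.

In a functional assay on SK-BR-3 cells (Homo sapiens) for cytotoxicity, read by MTT assay, with a stated time of 72 h (on this read-out higher numbers stand for an effect only at larger amounts of compound and lower numbers for an effect already at smaller amounts), compound 1 `CCc1cccc2c(O)c(-c3occ(C)c3C(=O)O)ccc12` gives 1 ug/mL as its value, while compound 2 `CCOC(=O)c1c(C)coc1-c1ccc2c(CC)cccc2c1OC` gives 2.5 ug/mL and so holds the higher of the two numbers, a gap beyond the usual scatter. Compound 3 `CCc1cccc2c(OC(C)=O)c(-c3occ(C)c3COC(C)=O)ccc12` has a group linked through a methyl carbon rather than a carbonyl at this place, and its > 10 ug/mL is a limit of the assay. Compound 4 `CCOCc1c(C)coc1-c1ccc2c(CC)cccc2c1OC` has ethoxymethyl in place of ethoxycarbonyl on an aromatic carbon on an aromatic carbon of a five-membered aromatic ring with 1 oxygen. For the measured compounds named here, no measured pair isolates this change. An upward step a 2.4-fold higher number from compound 2 to compound 4 (0.38 log units; beyond the scatter) is expected, only modestly beyond the scatter. For compound 4 the estimated value is 6 ug/mL within an expected range of 2.5 ug/mL to 14 ug/mL in this assay once measured.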

Compound 4, concentration for half-maximal effect: > 10 ug/mL
Compound 4: no number, only a limit (the forecaster's own chance of this, stated with the estimate: 30%); at least 1.6-fold (0.22 log units) between middle value and limit.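

In this assay, ethoxymethyl in place of ethoxycarbonyl on this aromatic carbon gives an at least 4.0-fold higher number from compound 2 to compound 4 (0.60 log units; beyond the scatter), the only step shown that isolates a single change at this place on the shared core. Compound 4 reads > 10 ug/mL, which is a limit of the assay and not a number. The step therefore fixes a direction and a minimum size, and its true size stays unknown: the limit of > 10 ug/mL in this assay, at which 2 of the 4 values shown sit.

From the compounds shown here alone, whether an amide or a longer ester chain on this carbon would keep the number of compound 2 stays open. The compounds shown also cannot tell whether the carbonyl alone or the whole ester matters here.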